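Compound 1 and its hexyl amide, compound 3

The compounds below may be only part of what the source reports. "The series", "measured", "known", "first", "only" and "open" are said of these compounds alone.

compound 1 `COC(=O)c1cc(/C=C\c2cc(OC)ccc2OC)ccc1OC`: 20100 nM
compound 2 `COc1ccc(OC)c(C#Cc2ccc(OC)c(C(=O)O)c2)c1`: 32300 nM

Both values come from a functional assay on HCT-116 cells (Homo sapiens) for antiproliferative activity (on this read-out lower numbers stand for stronger inhibition of growth and higher numbers for weaker inhibition of growth), and lie within the scatter of each other, so compound 1 is not separated from compound 2. Compound 3 `CCCCCCNC(=O)c1cc(/C=C\c2cc(OC)ccc2OC)ccc1OC`, not yet measured, differs from compound 1 by hexylamino in place of methoxy on a carbonyl carbon with hexylamino in place of methoxy on a carbonyl carbon. Among the measured compounds shown here, no measured pair shows this kind of change, so any expectation remains loose. In this assay the expected 2.2-fold lower number from compound 1 to compound 3 (0.35 log units; beyond the scatter) is modest and points towards a lower number, only just beyond the scatter. The estimate for compound 3 is 9000 nM with an expected range from 2500 nM to 35000 nM.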

Compound 3, concentration for 50% growth inhibition: 21100 nM
Compound 3: middle estimate off by 2.3-fold (0.37 log units), on the low side; measured number inside the range.
By their numbers in this assay, from the lowest: compounds 1, 3 and 2 (each within the scatter of the next).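

In this assay, hexylamino in place of methoxy on a carbonyl carbon gives a 1.0-fold higher number from compound 1 to compound 3 (0.02 log units; within the scatter). Among the compounds shown here, this is the first reading at this position: methoxycarbonyl and hexylcarbamoyl are not separated, so the hexyl chain and the amide hydrogen together bring no measurable shift in growth inhibition. No measured data here explain this outcome. Open, from the compounds shown here alone, is whether a shorter chain such as methylamino, or an unsubstituted amine on the same carbonyl carbon, would also stay within the scatter of compound 1. Going by these compounds, a carboxylic acid in place of methoxy on this core also remains open.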